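Will compound 3 stay at the toxicity limit?

This account rests on a few compounds, and the source may have more. Where it says the series, first, only, none or still open, it means among the compounds named here.

Measured in an ADME assay on MT4 cells (Homo sapiens) for cytotoxicity, read by MTT assay, with a stated time of 5 days; on this read-out lower numbers stand for higher toxicity in this test and higher numbers for lower toxicity in this test:
- compound 1 (`COc1cc2nc([S+]([O-])CC(=O)Nc3ccccc3F)nc(Nc3c(Cl)cc(/C=C/C#N)cc3Cl)c2cc1OC`): > 208000 nM (a limit)
- compound 2 (`COc1cc2nc([S+]([O-])CC(=O)Nc3ccc(S(N)(=O)=O)cc3)nc(Nc3c(Cl)cc(/C=C/C#N)cc3Cl)c2cc1OC`): > 189000 nM (a limit)

Compound 2 has no exact number and stands only at its limit (> 189000 nM). Compound 3 (`COc1cc2nc([S+]([O-])CC(=O)Nc3c(C)cc(C)cc3C)nc(Nc3c(Cl)cc(/C=C/C#N)cc3Cl)c2cc1OC`) carries 2,4,6-trimethylphenyl in place of 4-sulfamoylphenyl on an amide-type nitrogen. For the measured compounds named here, the one measured change at this place gives no size to build on (a step that the two limits leave unreadable from compound 1 to compound 2). With no readable step behind it, the expected change is no more than the usual scatter in this assay (an at least 1.2-fold lower number from compound 2 to compound 3 (0.10 log units; that floor lies within the scatter)). Compound 3 is estimated at 150000 nM (expected range 50000 nM to 220000 nM).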

Compound 3, half-maximal cytotoxic concentration: 8870 nM
For compound 3 the middle estimate is 17-fold (1.23 log units) above the measured one; the measured number lies below the stated range.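

In this assay, the group on the amide-type nitrogen proves able to change the read-out: 2,4,6-trimethylphenyl gives an at least 21-fold lower number from compound 2 to compound 3 (1.32 log units; beyond the scatter), and against 2-fluorophenyl it gives an at least 23-fold lower number from compound 1 to compound 3 (1.37 log units; beyond the scatter). For the compounds shown here, compound 3 is thus the first compound here with an exact number, so toxicity in this test can appear through a change at this place alone. Both steps give only minimum sizes, because each starts from a limit of the assay: the limit of > 189000 nM in this assay, at which 1 of the 3 values shown sits.

Open, going by these compounds, is whether all of the methyl groups are needed for this drop. Also open, on these data alone, is where a plain phenyl, or a phenyl carrying a carboxylic acid or an amine, would fall.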